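Swapping a Branched Chain for a Ring on the Agonist

This account rests on a few compounds, and the source may have more. Where it says the series, first, only, none or still open, it means among the compounds named here.

Compound 1 `CC(C)(C)CCc1cnc(CCc2ccc(-c3ccccc3C(=O)O)cc2)[nH]1` gives 39 nM in an in vitro functional assay on cells for agonist activity at Bombesin receptor subtype-3 (Homo sapiens), read by luminescence and calcium flux; a higher number here means that more compound is needed for the effect, a lower number that less compound is needed.
Compound 2 `CCCCc1cnc(/C=C/c2ccc(-c3ccccc3C(=O)O)cc2)[nH]1` gives 4380 nM in this assay.

Compound 1 stands lowest of these two numbers, and the gap from compound 2 lies well beyond the scatter. Compound 3, `O=C(O)c1ccccc1-c1ccc(CCc2ncc(C3CCCCC3)[nH]2)cc1`, is not yet measured; it differs from compound 1 by cyclohexyl in place of 3,3-dimethylbutyl on an aromatic carbon. Among the measured compounds shown here, no measured pair shows this change, so its effect is unknown. Both groups carry the same count of carbons, and a small step in either direction, or none beyond the scatter, is expected in this assay. For compound 3 the estimate is 60 nM, within 15 nM to 250 nM, which is expected to mean a 1.5-fold higher number from compound 1 to compound 3 (0.19 log units; within the scatter).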

Compound 3, half-maximal effective concentration: 375 nM
Beside the measured number, compound 3's estimate is 6.3-fold (0.80 log units) below it; the whole stated range lies below it.
By their numbers in this assay, from the lowest: compound 1; then compound 3; then compound 2.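

At this position on the five-membered aromatic ring, carbon count alone does not settle the outcome: in this assay, replacing 3,3-dimethylbutyl with cyclohexyl, which has the same count of carbons, gives a 9.6-fold higher number from compound 1 to compound 3 (0.98 log units; beyond the scatter). The two groups are therefore not interchangeable here, at least on the evidence of this single pair. Nothing available explains the step.

As far as these compounds go, whether an unbranched hexyl chain, a smaller cyclopentyl ring or a cyclohexylmethyl group would fall nearer compound 1 or compound 3 remains open.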